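Methylamino to ethylamino on two benzophenone-type cores

This account rests on a few compounds, and the source may have more. Where it says the series, first, only, none or still open, it means among the compounds named here.

Measured so far in a functional assay on A549 cells (Homo sapiens) for antiproliferative activity, read by MTT assay, with a stated time of 48 h; a higher number here means a weaker inhibitor, a lower number a stronger inhibitor:
- compound 1 `CNCC(=O)Nc1cc(OC)ccc1C(=O)c1ccc2c(c1)C=CC(C)(C)O2`: 800 nM
- compound 2 `CCNCC(=O)Nc1cc(OC)ccc1C(=O)c1ccc2c(c1)C=CC(C)(C)O2`: 1300 nM
- compound 3 `C=C(c1ccc(OC)cc1NC(=O)CNC)c1ccc(OC)c2c1OC(C)(C)C=C2`: 150 nM

Compound 3 stands lowest of the three in this assay; the gaps to compound 1 and to compound 2 are both beyond the scatter. The difference between the core of compound 3 and the core of compound 1 is not broken down here.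

Within the core of compound 1, the change methyl in place of hydrogen on a saturated chain carbon bound to an amine nitrogen gave a 1.6-fold higher number from compound 1 to compound 2 (0.21 log units; within the scatter), a step that lies within the scatter, so compound 1 and compound 2 are read as equivalent in this assay.

Compound 4 `C=C(c1ccc(OC)cc1NC(=O)CNCC)c1ccc(OC)c2c1OC(C)(C)C=C2` has not yet been measured. It carries the same change on the core of compound 3: methyl in place of hydrogen on a saturated chain carbon bound to an amine nitrogen. On the strength of the earlier step from compound 1 to compound 2, the step is expected to be a 1.3-fold higher number from compound 3 to compound 4 (0.12 log units; within the scatter), again within the scatter; this rests only on that one pair, and a second core may not follow. Compound 4 is estimated at 200 nM in this assay, with a range from 100 nM to 420 nM.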

Compound 4, half-maximal inhibitory concentration: 970 nM
Compound 4: the middle estimate sits 4.9-fold (0.69 log units) below what was measured, outside the stated range (above it).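

In this assay, methylamino to ethylamino gave a 6.5-fold higher number from compound 3 to compound 4 (0.81 log units; beyond the scatter), so the change does not carry over at the same size from one core to the other: the same change on two cores in this assay, a 1.6-fold higher number (0.21 log units; within the scatter) from compound 1 to compound 2 and a 6.5-fold higher number (0.81 log units; beyond the scatter) from compound 3 to compound 4, 4.0-fold (0.60 log units) apart, beyond the scatter of two such steps

Read on the core of compound 1 alone, the change would pass as neutral, whereas on the core of compound 3 it gives a real loss of activity, so in these two pairs the size of the step depends on the core. This does not show which feature of the two cores sets the gap, gives no cause for it, and, resting on two pairs only, sets no rule for the series.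

Open, on these data alone, is how the core of compound 3 responds to other groups on the same amine, such as the primary amine, dimethylamino, a longer chain such as propyl, or a cyclic amine such as pyrrolidine. Also open is which part of the difference between the two cores matters, as no compound shown separates those parts.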